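Trimming the Methyl from the Hydroxypiperidine Ring

The source may report more compounds than this note shows. Statements on the series, on what has been measured and on what is new or still open speak of the compounds shown alone.

Within the data shown here, compound 2 `Cc1nc(N2CCC(C)(O)CC2)nc2ccc(NC(=O)COc3ccc(Cl)cc3)cc12` gives 237 nM in an assay on CHO-K1 cells for displacement of a labelled ligand from melanin-concentrating hormone receptor 1 (Homo sapiens), with a stated time of 2 h (on this read-out higher numbers stand for weaker inhibition and lower numbers for stronger inhibition), the higher of the two numbers measured so far. Compound 1 `Cc1nc(N2CCN(C3CCCC3)CC2)nc2ccc(NC(=O)COc3ccc(Cl)cc3)cc12` gives 96 nM, and the step of a 2.5-fold higher number from compound 1 to compound 2 (0.39 log units; beyond the scatter) exchanges the entire ring attached to the shared core. Compound 3 `Cc1nc(N2CCC(O)CC2)nc2ccc(NC(=O)COc3ccc(Cl)cc3)cc12` differs from compound 2 by hydrogen in place of methyl on a saturated ring carbon. Among the measured compounds shown here, no measured step touches this methyl alone, so the one known step offers no direct guide. A change within the scatter is expected for compound 3, at a 1.3-fold higher number from compound 2 to compound 3 (0.10 log units; within the scatter). Compound 3 is therefore estimated at 300 nM, within 120 nM to 800 nM.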

Compound 3, half-maximal inhibitory concentration: 150 nM
Estimate against measurement, compound 3: 2.0-fold (0.30 log units) above; the measured number falls inside the stated range.
By their numbers in this assay, from the lowest: compounds 1, 3 and 2 (each within the scatter of the next, the first and the last beyond it).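

In this assay, hydrogen in place of methyl on this saturated ring carbon gives a 1.6-fold lower number from compound 2 to compound 3 (0.20 log units; within the scatter), so this methyl alone has no effect that can be told from the scatter. The 4-hydroxypiperidin-1-yl ring in place of 4-cyclopentylpiperazin-1-yl gives a 1.6-fold higher number from compound 1 to compound 3 (0.19 log units; within the scatter), so this whole-ring exchange also stays within the scatter, unlike the exchange to the 4-hydroxy-4-methylpiperidin-1-yl ring. Nothing available explains these numbers.

On these data alone, whether an ethyl group on this ring carbon, or an amine in place of the hydroxyl group, would move the number stays open.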